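Bromo to methoxy exchange on two related cores

This account rests on a few compounds, and the source may have more. Where it says the series, first, only, none or still open, it means among the compounds named here.

Compound 1 `COc1cc(C=C(C(=O)/C=C/c2cccc(OC)c2OC)C(=O)/C=C/c2cccc(OC)c2OC)cc(Br)c1O` and compound 2 `COc1cc(C=C(C(=O)/C=C/c2cccc(OC)c2OC)C(=O)/C=C/c2cccc(OC)c2OC)cc(OC)c1O` share one core; compound 3 `COc1ccc(/C=C/C(=O)C(=Cc2cc(Br)c(O)c(OC)c2)C(=O)/C=C/c2ccc(OC)cc2OC)c(OC)c1` and compound 4 `COc1ccc(/C=C/C(=O)C(=Cc2cc(OC)c(O)c(OC)c2)C(=O)/C=C/c2ccc(OC)cc2OC)c(OC)c1` share another. The two cores have the same atoms joined differently, and the difference between them is not broken down here. In a functional assay on SW480 cells (Homo sapiens) for antiproliferative activity, read by sulforhodamine B assay, with a stated time of 48 h (on this read-out higher numbers stand for weaker inhibition and lower numbers for stronger inhibition), compound 1 gives 260 nM, compound 2 gives 420 nM and compound 3 gives 1480 nM. Compound 3 stands highest of the three measured numbers, beyond the scatter from both compound 1 and compound 2.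

The change from compound 1 to compound 2 is methoxy in place of bromo on an aromatic carbon and gives a 1.6-fold higher number from compound 1 to compound 2 (0.21 log units; within the scatter). The change from compound 3 to compound 4 is methoxy in place of bromo on an aromatic carbon, the same change at the same kind of place. Within the data shown here, for compound 4 a step of about the same size is expected, a 1.5-fold higher number from compound 3 to compound 4 (0.17 log units; within the scatter), which rests on the single earlier step of a 1.6-fold higher number from compound 1 to compound 2 (0.21 log units; within the scatter) seen on the other core, with the small number of examples as the main uncertainty. In this assay compound 4 is expected to give about 2200 nM, within a range from 1000 nM to 4800 nM.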

Compound 4, half-maximal inhibitory concentration: 850 nM
Compound 4: the middle estimate sits 2.6-fold (0.41 log units) above what was measured; measured number below the stated range.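

Carried from one core to the other, methoxy in place of bromo does not behave as a single transferable step in this assay: the same change on two cores in this assay, a 1.6-fold higher number (0.21 log units; within the scatter) from compound 1 to compound 2 and a 1.7-fold lower number (0.24 log units; within the scatter) from compound 3 to compound 4, 2.8-fold (0.45 log units) apart, beyond the scatter of two such steps

On the core of compound 3, the new step is a 1.7-fold lower number from compound 3 to compound 4 (0.24 log units; within the scatter), so taken alone it does not separate bromo from methoxy on that core, and the same holds for the earlier step on the core of compound 1. The result therefore shows that the effect of this change depends on the core in this small set, but with one pair on each core it does not show how large that dependence is, which feature of the cores is responsible, or what would happen on a further core.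

The compounds shown leave open how an amine, a chloro group or a carboxylic acid would read in place of bromo, ortho to the hydroxy group, on either core. They also leave open whether a third arrangement of the two dimethoxyphenyl arms would follow the core of compound 1, the core of compound 3 or neither.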